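Working notes: replacing thiophen-2-yl with 4-bromophenyl

A few compounds are considered here, and "the series" means these few. Any claim that something is new, unique, unknown or untested is made for them only; others in the source may bear on it.

Compound 1 `COc1ccc(C(=O)C=CNc2cc(-c3ccccc3)nn2-c2ccccc2)cc1`: 2030 nM
Compound 2 `c1ccc(-c2nn(-c3ccccc3)c3nccc(-c4cccs4)c23)cc1`: 39300 nM

In a functional assay on HepG2 cells (Homo sapiens) for inhibition, read by MTT assay, with a stated time of 48 h (a higher number here means a weaker inhibitor, a lower number a stronger inhibitor), compound 2 has the higher of the two numbers, 39300 nM, and is the weaker inhibitor, beyond the scatter from compound 1. Compound 3 `Brc1ccc(-c2ccnc3c2c(-c2ccccc2)nn3-c2ccccc2)cc1` carries 4-bromophenyl in place of thiophen-2-yl on an aromatic carbon, opposite the ring nitrogen: 4-bromophenyl in place of thiophen-2-yl on an aromatic carbon. For the measured compounds named here, no measured pair shows this kind of change, so the only anchor is compound 2 at 39300 nM. No step beyond the scatter is expected, a 1.4-fold lower number from compound 2 to compound 3 (0.15 log units; within the scatter). For compound 3 the estimated value is 28000 nM, with an expected range of 8000 nM to 80000 nM.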

Compound 3, half-maximal inhibitory concentration: 49900 nM
For compound 3 the middle estimate is 1.8-fold (0.25 log units) below the measured one; low and high end bracket the measured number.
By their numbers in this assay, from the lowest: compound 1; then compounds 2 and 3 (each within the scatter of the next).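

In this assay, for the compounds shown here, 4-bromophenyl in place of thiophen-2-yl on the aromatic carbon opposite the ring nitrogen (a 1.3-fold higher number from compound 2 to compound 3 (0.10 log units; within the scatter)) gives the only one-place pair. At this position, the five-membered sulfur-containing aromatic ring and the six-membered carbon-only aromatic ring bearing bromine cannot be told apart in this read-out. No supporting evidence bears on this result.

Only these two aromatic groups are shown here, so the effect of an amine, a carboxylic acid or a longer alkyl chain at this position remains open. Unsubstituted phenyl would be needed to isolate the contribution of the bromine.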